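The compounds below may be only part of what the source reports. "The series", "measured", "known", "first", "only" and "open" are said of these compounds alone.

Series notes. Compound 1 `COc1ccc(C(=O)NNC(=O)/C=C/c2ccc(O)c(OC)c2)cc1` is measured in an ADME assay on NL20 cells (Homo sapiens) for antiproliferative activity, read by MTT assay, with a stated time of 24 h; on this read-out higher numbers stand for weaker inhibition and lower numbers for stronger inhibition; for compound 1 the result is a limit of the assay, > 10000 nM. Compound 2 `COc1ccc(C(=O)NNC(=O)/C=C/c2ccc(O)c(O)c2)cc1` gives 9390 nM in this assay. Compound 3 `COc1ccc(C(=O)NNC(=O)/C=C/c2cc(OC)c(O)c(OC)c2)cc1` gives 9420 nM in this assay, a number within the scatter of compound 2. The change hydrogen in place of methyl on an oxygen on an aromatic ring made the step of an at least 1.0-fold lower number from compound 1 to compound 2 (0.02 log units; that floor lies within the scatter), a floor set by the limit of > 10000 nM in this assay, at which 1 of the 3 values shown sits. The change methoxy in place of hydrogen on an aromatic carbon made the step of an at least 1.0-fold lower number from compound 1 to compound 3 (0.02 log units; that floor lies within the scatter), likewise a floor set by the limit of > 10000 nM in this assay, at which 1 of the 3 values shown sits. Compound 4 `COc1cc(/C=C/C(=O)NNC(=O)c2ccc(O)cc2)cc(OC)c1O` is not yet measured. It differs from compound 3 by hydrogen in place of methyl on an oxygen on an aromatic ring, the same change as hydrogen in place of methyl on an oxygen on an aromatic ring, at a place described in the same words; the two cores differ by methoxy in place of hydrogen on an aromatic carbon. Beside the earlier step, the expected step is a 1.0-fold lower number from compound 3 to compound 4 (0.02 log units; within the scatter), resting on an at least 1.0-fold lower number from compound 1 to compound 2 (0.02 log units; that floor lies within the scatter) sitting at the floor. Compound 4 is estimated at 9000 nM in this assay, between 4000 nM and 20000 nM.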

Compound 4, half-maximal inhibitory concentration: > 10000 nM
Compound 4: no number, only a limit; the forecaster's own chance of this, stated with the estimate: 40%; at least 1.1-fold (0.04 log units) between middle value and limit.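

In this assay compound 4 gives > 10000 nM, a limit of the assay and not a number. Hydrogen in place of methyl on an oxygen on an aromatic ring reads as an at least 1.0-fold higher number from compound 3 to compound 4 (0.02 log units; that floor lies within the scatter), and set beside the earlier step it stands as follows: the same change on two cores in this assay, an at least 1.0-fold lower number (0.02 log units; that floor lies within the scatter) from compound 1 to compound 2 and an at least 1.0-fold higher number (0.02 log units; that floor lies within the scatter) from compound 3 to compound 4; the limit leaves it open whether they differ. Carrying this change from one core to another is therefore neither confirmed nor refuted, and both steps are only floors tied to one limit: the limit of > 10000 nM in this assay, at which 2 of the 4 values shown sit.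

Open, from the compounds shown here alone, is how methoxy to hydroxy would read on a core whose values stand clear of that limit. Also open, going by these compounds, is what an amine or a carboxylic acid in place of that hydroxy would give in this assay.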